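Swapping chlorine for bromine: does the half-life move?

The compounds below may be only part of what the source reports. "The series", "measured", "known", "first", "only" and "open" are said of these compounds alone.

Compound 1 `O=C(Nc1cc(C(F)(F)F)cc(C(F)(F)F)c1)c1cc(Br)c(-c2ccccc2)cc1O` gives 2.65 h
Compound 2 `N#Cc1ccc(NC(=O)c2ccc3cccnc3c2O)cc1` gives 2.07 h
Compound 3 `O=C(Nc1cc(C(F)(F)F)cc(C(F)(F)F)c1)c1ccc(Cl)cc1O` gives 2.65 h

These half-lives all come from an ADME assay on microsomes from liver (Homo sapiens) for metabolic stability, read by LC-MS, using NADPH (a lower number here means that the compound disappears faster, a higher number that the compound lasts longer), and sit close together. Compound 3 (2.65 h) is level with compound 1 (2.65 h), and compound 2 (2.07 h) lies within the usual scatter of both. Among the compounds with values here, the measured compounds differ from one another in more than one place, so no measured pair shows what a single change does.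

Compound 4 `O=C(Nc1cc(C(F)(F)F)cc(C(F)(F)F)c1)c1cc(Br)ccc1O` has not yet been measured. It differs from compound 3 in one place: 5-bromo-2-hydroxyphenyl in place of 4-chloro-2-hydroxyphenyl on a carbonyl carbon. In words, 5-bromo-2-hydroxyphenyl stands in place of 4-chloro-2-hydroxyphenyl on a carbonyl carbon.

The data hold no direct test of this swap. One indirect hint is that compound 1 also carries a bromine and gives (2.65 h), which matches compound 3 at the digits shown. In this assay the expectation is therefore no step beyond the scatter, with neither direction favoured. The estimated change is a 1.0-fold lower number from compound 3 to compound 4 (0.01 log units; within the scatter) and would stay inside that scatter. Compound 4 is estimated at 2.6 h with an expected range of 1.6 h to 4.2 h for its measurement.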

Compound 4, half-life: 0.867 h
Compound 4: middle estimate off by 3.0-fold (0.48 log units), on the high side, outside the stated range (below it).
By their numbers in this assay, from the lowest: compound 4; then compounds 2, 1 and 3 (each within the scatter of the next).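

In this assay, the swap on the carbonyl carbon, 5-bromo-2-hydroxyphenyl in place of 4-chloro-2-hydroxyphenyl, turns out not to be neutral: it gives a 3.1-fold lower number from compound 3 to compound 4 (0.49 log units; beyond the scatter) and so shows that this ring is sensitive to the change. The swap alters both the halogen and its place on the ring, so this single step covers two changes at once. Hydrogen in place of phenyl on an aromatic carbon gives a 3.1-fold lower number from compound 1 to compound 4 (0.49 log units; beyond the scatter) with the bromine kept, which shows that carrying a bromine does not by itself fix the half-life, and nothing in the data available explains either step.

Which part of the first swap, the element or its place, accounts for the step stays open, and a 5-chloro-2-hydroxyphenyl group would separate the two. From the compounds shown here alone, it is also open whether the longer half-life seen with phenyl is special to that ring, or whether a smaller group such as methyl, or an amine, on the same aromatic carbon would do the same.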